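The compounds below may be only part of what the source reports. "The series", "measured", "known", "first", "only" and "open" are said of these compounds alone.

Measured so far:
compound 1 `COc1ccc(-c2cc(/C=C/C(=O)c3cc(OC)c(OC)c(OC)c3)nc3cc(-c4ccccc4)nn23)cc1OC` — 35000 nM
compound 2 `COc1cc(/C=C/C(=O)c2cc(-c3cc(OC)c(OC)c(OC)c3)n3nc(-c4ccccc4)cc3n2)cc(OC)c1OC` — 41000 nM

In an ADME assay on HEK293 cells (Homo sapiens) for antiproliferative activity, read by MTT assay, with a stated time of 24 h (a lower number here means a stronger inhibitor, a higher number a weaker inhibitor), compound 1 gives 35000 nM and compound 2 gives 41000 nM; the two numbers lie within the scatter of each other, so on the numbers shown compound 1 is not set apart from compound 2. Compound 3 `COc1ccc(C(=O)/C=C/c2cc(-c3ccc(OC)c(OC)c3)n3nc(-c4ccccc4)cc3n2)cc1OC` is not yet measured in this assay. It differs from compound 1 in one place: hydrogen in place of methoxy on an aromatic carbon. Going by the values given here, no measured pair shows this change. The step from compound 1 to compound 3 is expected to be small, if anything toward a higher number, and is estimated at a 1.2-fold higher number from compound 1 to compound 3 (0.08 log units; within the scatter). Compound 3 is expected to give about 42000 nM, in the range 20000 nM to 90000 nM.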

Compound 3, half-maximal inhibitory concentration: 32500 nM
For compound 3 the middle estimate is 1.3-fold (0.11 log units) above the measured one; the measured number falls inside the stated range.
By their numbers in this assay, from the lowest: compounds 3, 1 and 2 (each within the scatter of the next).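

In this assay, going by these compounds alone, the first measured pair for hydrogen in place of methoxy on this aromatic carbon, 3,4,5-trimethoxyphenyl to 3,4-dimethoxyphenyl, gives a 1.1-fold lower number from compound 1 to compound 3 (0.03 log units; within the scatter) and so does not separate the two compounds. At this position, methoxy and hydrogen are therefore not told apart by this read-out. No other measurement bears on this result. Still open, as far as these compounds go, is whether an amine, a carboxylic acid or a longer chain such as propoxy on this carbon would give a step beyond the scatter.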